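A few compounds are considered here, and "the series" means these few. Any claim that something is new, unique, unknown or untested is made for them only; others in the source may bear on it.

Of the compounds shown here, two sharing one core have so far been measured in a functional assay on HT-29 cells (Homo sapiens) for cytotoxicity, read by MTT assay, with a stated time of 24 h (a lower number here means a stronger inhibitor, a higher number a weaker inhibitor), and they cannot be told apart. Among the compounds with values here, compound 1 (`Cn1c(-c2ccc(NC(=O)CCl)cc2)nc(-c2ccccc2)c1-c1ccccc1`) gives 28.7 ug/mL while compound 2 (`Cn1c(-c2ccc(NC(=O)CSc3nc4ccccc4s3)cc2)nc(-c2ccccc2)c1-c1ccccc1`) gives 18 ug/mL so compound 2 stands within the usual scatter of its only neighbour. Compound 3 (`Cn1c(-c2ccc(NC(=O)CSC3=NCCS3)cc2)nc(-c2ccccc2)c1-c1ccccc1`) differs from compound 2 on a sulfur bound to a saturated chain carbon: 1,3-benzothiazol-2-yl leaves and a five-membered non-aromatic ring enters, which amounts to a group of 5 heavy atoms (3 carbon, 1 nitrogen, 1 sulfur; one five-membered non-aromatic ring with 2 hetero atoms) in place of a group of 9 heavy atoms (7 carbon, 1 nitrogen, 1 sulfur; one five-membered aromatic ring with 2 hetero atoms, one six-membered aromatic ring of carbon only), on a sulfur at that place. Within the data shown here, no measured step covers this exact swap. The nearest one, a 1.6-fold lower number from compound 1 to compound 2 (0.20 log units; within the scatter) when (1,3-benzothiazol-2-yl)sulfanyl replaces chloro, stays small, so no step beyond the scatter is expected in this assay here. The estimated step is a 1.1-fold higher number from compound 2 to compound 3 (0.05 log units; within the scatter) on this reasoning. Compound 3 is expected at 20 ug/mL with a range from 9 ug/mL to 45 ug/mL as its estimate.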

Compound 3, half-maximal inhibitory concentration: 21 ug/mL
Compound 3: the middle estimate sits 1.1-fold (0.02 log units) below what was measured; measured number inside the range.
By their numbers in this assay, from the lowest: compounds 2, 3 and 1 (each within the scatter of the next).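

In this assay, the group on the sulfur can change from 1,3-benzothiazol-2-yl, with its two aromatic rings, to a single five-membered non-aromatic ring with no step beyond the scatter: a 1.2-fold higher number from compound 2 to compound 3 (0.07 log units; within the scatter). Set against the chloro compound, the new group also stays within the scatter, with a 1.4-fold lower number from compound 1 to compound 3 (0.14 log units; within the scatter), so the three groups at this place cannot be told apart in this assay. No measurement is available to explain how close these numbers lie. Still open, going by these compounds, is whether a group of another kind on the saturated chain carbon, such as an amine or a carboxylic acid, would produce a step beyond the scatter. On these data alone, a longer chain carrying the sulfur is an equally open case.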